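The compounds below may be only part of what the source reports. "The series", "measured", "known", "first", "only" and "open" are said of these compounds alone.

Measured compounds:
Compound 1 `O=C1O[C@H]([C@@H](O)Cn2cc(-c3cccc(O)c3)nn2)C(OCc2ccccc2)=C1OCc1ccccc1`: in a functional assay on A549 cells (Homo sapiens) for antiproliferative activity, read by MTT assay, with a stated time of 72 h (on this read-out higher numbers stand for weaker inhibition and lower numbers for stronger inhibition), compound 1 gives 59900 nM.
Compound 2 `COc1ccccc1-c1cn(C/C=C2\OC(=O)C(OCc3ccccc3)=C2OCc2ccccc2)nn1`: in this assay compound 2 gives only a limit of the assay, > 100000 nM.

Among the measured compounds shown here, compound 1 holds the only numerical value in this small set; the other entry is a limit, (the limit of > 100000 nM in this assay, at which 1 of the 2 values shown sits), so compound 1 cannot be ranked against anything measured. What compound 1 and compound 2 show together is simply that both sit at the weak end of the scale.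

Compound 3 `O=C1O[C@H]([C@@H](O)Cn2cc(CNS(=O)(=O)c3ccc(Cl)cc3)nn2)C(OCc2ccccc2)=C1OCc1ccccc1` has not yet been measured. It differs from compound 1 in one place: (((4-chlorophenyl)sulfonyl)amino)methyl in place of 3-hydroxyphenyl on an aromatic carbon. For the measured compounds named here, no step between two measured compounds in this assay is available, so the effect of such a change is not anchored by any measured pair, and the expectation for compound 3 rests on the value of compound 1 alone. For compound 3 the expected step is a 1.0-fold higher number from compound 1 to compound 3 (0.00 log units; within the scatter), which is not beyond the usual scatter. Compound 3 is therefore estimated at 60000 nM, with a range from 20000 nM to 180000 nM, and a real chance that this assay returns only a limit.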

Compound 3, half-maximal inhibitory concentration: 2870 nM
The estimate for compound 3 lay 21-fold (1.32 log units) above the measured number, outside the stated range (below it).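

The result shows that in this assay the group on this aromatic carbon of the five-membered aromatic ring with 3 nitrogen strongly affects the read-out: replacing 3-hydroxyphenyl with (((4-chlorophenyl)sulfonyl)amino)methyl gives a 21-fold lower number from compound 1 to compound 3 (1.32 log units; beyond the scatter). Among the compounds shown here, this is the first measured step in the set, and it moves compound 3 away from the weak end of the scale where the earlier compounds sat, so the larger entering group, with its aromatic ring set further out through a chain containing the sulfonyl group, is compatible with stronger inhibition on the core of compound 1. Nothing measured here gives a reason for the step, and the two groups differ in several counted features at once, so it cannot be assigned to the sulfonyl group, the chlorine or the linking chain on its own.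

The compounds shown leave open which part of the entering group carries the step, a question that the same group without its chlorine, or with a plain carbonyl in place of the sulfonyl, could help to separate. Going by these compounds, it also remains open how a simple amine, a carboxylic acid or a longer chain on this aromatic carbon would read in this assay.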